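Swapping a methoxyphenyl for a difluorophenyl group

A few compounds are considered here, and "the series" means these few. Any claim that something is new, unique, unknown or untested is made for them only; others in the source may bear on it.

Of the compounds shown here, three sharing one core have been tested in a functional assay on U-87MG ATCC cells for inhibition, with U-87 MG (Homo sapiens) as the target, read by MTT assay, with a stated time of 48 h; on this read-out lower numbers stand for stronger inhibition and higher numbers for weaker inhibition. Compound 1, `COc1ccccc1-c1csc(N/N=C/c2ccc(F)c(F)c2)n1`, gives 40600 nM. Compound 2, `COc1cc(/C=N/Nc2nc(-c3ccccc3)cs2)cc(Br)c1OC`, gives 74100 nM in this assay, a number higher than that of compound 1 by an amount that lies within the usual scatter, so the two cannot be ranked. Compound 3, `COc1cc(/C=N/Nc2nc(-c3cc(C(F)(F)F)cc(C(F)(F)F)c3)cs2)cc(Br)c1OC`, reaches only a limit of this assay rather than a number, > 100000 nM. Of the two real numbers, compound 1 stands lowest, and the limit of > 100000 nM in this assay, at which 1 of the 3 values shown sits, marks where compound 3 sits.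

Compound 4, `Fc1ccc(/C=N/Nc2nc(-c3ccc(F)c(F)c3)cs2)cc1F`, has not yet been measured. It differs from compound 1 in one place: 3,4-difluorophenyl in place of 2-methoxyphenyl on an aromatic carbon. With this change both ends of the molecule carry the same 3,4-difluorophenyl group.

Going by the values given here, no step between two measured compounds differing in one place is available, so the direction of this change rests only on where compound 1, compound 2 and compound 3 stand. All three sit at weak inhibition, and compound 3 reaches a limit. The step of a 1.5-fold higher number from compound 1 to compound 4 (0.17 log units; within the scatter) is therefore expected to be small, within or only slightly beyond the scatter, leaning toward weaker inhibition. Compound 4 is estimated at 60000 nM in this assay, with a likely range from 20000 nM to 180000 nM.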

Compound 4, half-maximal inhibitory concentration: 43900 nM
For compound 4 the middle estimate is 1.4-fold (0.14 log units) above the measured one; the measured number falls inside the stated range.
By their numbers in this assay, from the lowest: compounds 1, 4 and 2 (each within the scatter of the next). At a limit, above all of these: compound 3.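

In this assay, this direct comparison at the aromatic carbon next to the ring nitrogen gives a 1.1-fold higher number from compound 1 to compound 4 (0.03 log units; within the scatter), so compound 1 and compound 4 cannot be told apart. Going by these compounds alone, the pair therefore shows something that the earlier compounds, with no one-place step among them, could not: in this setting, 2-methoxyphenyl, which counts 1 hydrogen-bond acceptor, and 3,4-difluorophenyl, which counts 0, give results that lie within the scatter of each other, although the two groups hold the same number of heavy atoms. Nothing measured here bears on why the two groups give such similar numbers.

This single pair leaves open whether the same holds when the other end of the molecule carries a different group, since both compounds share the 3,4-difluorophenyl group there. It also leaves open whether a phenyl ring bearing an amine or a carboxylic acid, or a longer alkyl chain in place of the ring, would at this position give a number that differs beyond the scatter.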